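The compounds below may be only part of what the source reports. "The series", "measured", "known", "first", "only" and "open" are said of these compounds alone.

Of the compounds shown here, two have numbers so far. Compound 1 `CC(C)NC(=O)/C=C1\CCc2ccc(F)cc21` carries an isopropylamino group on its carbonyl carbon, and compound 2 `NC(=O)/C=C1\CCc2cc(F)ccc21` carries a plain amide at that position. In a functional assay on the whole organism with Mus musculus as the target (on this read-out lower numbers stand for an effect already at smaller amounts and higher numbers for an effect only at larger amounts of compound), compound 1 gives 96 mg/kg, the higher of the two numbers, while compound 2 gives 56 mg/kg; the gap between them lies within the usual scatter of repeated measurements, so neither can be said to act at a smaller dose than the other.

Compound 3 `CCN(C)C(=O)/C=C1\CCc2ccc(F)cc21` is the next compound to be tested. It has the same atoms as compound 1, joined differently: ethyl(methyl)amino in place of isopropylamino on a carbonyl carbon. Going by the values given here, the hydrogen-bond donor of compound 1 is thereby gone, but no measured pair shows what such a change does here, since compound 2 differs from compound 1 in more than this one group. With the two numbers so close, the step from compound 1 to compound 3 is expected to be small, a 1.0-fold higher number from compound 1 to compound 3 (0.02 log units; within the scatter), not beyond the scatter in either direction. For compound 3 in this assay the estimate is 100 mg/kg, with a range from 40 mg/kg to 250 mg/kg.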

Compound 3, dose for half-maximal effect: 100 mg/kg
Compound 3: the middle estimate sits on the measured number at the digits printed, and the stated range covers the measured number.
By their numbers in this assay, from the lowest: compounds 2, 1 and 3 (each within the scatter of the next).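

Going by these compounds alone, this is the first pair that differs in one place only. In this assay, moving the same atoms around on the carbonyl carbon, so that isopropylamino becomes ethyl(methyl)amino and the amide hydrogen is lost, gives a 1.0-fold higher number from compound 1 to compound 3 (0.02 log units; within the scatter) and no readable change. For this pair, then, the hydrogen-bond donor on the amide nitrogen makes no difference that can be told apart from the ordinary spread of repeat measurements, so compound 1 and compound 3 count as equal on this read-out. Nothing measured on these compounds speaks to what lies behind this result.

The two groups compared have the same heavy atoms, so this pair says nothing about a group of a different size or kind on the carbonyl carbon, such as a longer chain like hexylamino or a carboxylic acid in place of the amide. As far as these compounds go, compound 2 differs from compound 1 in more than one place, so what its plain amide does on its own also remains open.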